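This account rests on a few compounds, and the source may have more. Where it says the series, first, only, none or still open, it means among the compounds named here.

Compound 1 `CCN1CCC2(CC1)CC(=O)c1ccc3ccccc3c1O2` gives >= 80000 nM in this assay.
Compound 2 `c1ccc2c3c(ccc2c1)CCC1(CCNCC1)O3` gives 20000 nM in this assay.
Compound 3 `O=C1CC2(CCNCC2)Oc2c1ccc1ccccc21` gives >= 80000 nM in this assay.

The three measured compounds were examined in a physicochemical assay for solubility, read by HPLC, at pH 6.5; on this read-out lower numbers stand for lower solubility and higher numbers for higher solubility. The value of compound 1 is a limit of the assay, not a number. The value of compound 3 is likewise a limit. Compound 2 is the only one of the three to give a number, and it stands apart from the two limits, with the limit of >= 80000 nM in this assay, at which 2 of the 3 values shown sit, marking where the other two sit.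

Compound 3 and compound 1 differ by one change, (ethyl in place of hydrogen on an amine nitrogen in a ring), and the step it made in this assay is a step that the two limits leave unreadable from compound 3 to compound 1: both ends are limits, so its size cannot be read. The core of compound 2 differs from that of compound 3, but the difference between the two cores is not broken down here.

Compound 4 `CCN1CCC2(CCc3ccc4ccccc4c3O2)CC1` has not yet been measured. It arises from compound 2 by the same change, (ethyl in place of hydrogen on an amine nitrogen in a ring), made on the same place as in the measured pair. The measured step gives no size, so the expectation for compound 4 rests mainly on compound 2, which gives 20000 nM. The step from compound 2 to compound 4 is expected to be about no change at the digits printed from compound 2 to compound 4 (within the scatter). Compound 4 is therefore estimated at 20000 nM, with a range from 5000 nM to 80000 nM.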

Compound 4, solubility: <= 10000 nM
Compound 4: no number, only a limit; the forecaster's own chance of this, stated with the estimate: 20%; middle value at least 2.0-fold (0.30 log units) from the limit.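

On the core of compound 2, ethyl in place of hydrogen on an amine nitrogen in a ring gave an at least 2.0-fold lower number from compound 2 to compound 4 (0.30 log units; that floor lies within the scatter) in this assay. The value of compound 4 is a limit of the assay and not a number, which means the step has only a floor; that floor does not by itself set compound 4 apart from compound 2 beyond the usual scatter, although the true step may be larger: the limit of <= 10000 nM in this assay, at which 1 of the 4 values shown sits. On the other core, the same change joins compound 3 to compound 1, and both ends of that step are limits, so it cannot be read and gives no size to set against the new step, which leaves it unshown whether the change carries from one core to the other with the same effect: the limit of >= 80000 nM in this assay, at which 2 of the 4 values shown sit.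

Going by these compounds, the true size of the ethyl step remains open on both cores, as does whether the two cores respond to it alike. Also open, on these data alone, is how a methyl, a longer chain or an amide on the same ring nitrogen would compare with the ethyl and with the hydrogen of compound 2 in this assay.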